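The source may hold more compounds than are shown below. What is called first, only, known or untested is meant among the compounds shown, and "the series" means these compounds.

Measured compounds in a functional assay on HT-29 cells (Homo sapiens) for cytotoxicity, read by MTT assay, with a stated time of 72 h; on this read-out higher numbers stand for weaker inhibition and lower numbers for stronger inhibition:
compound 1 `Cc1c(C(=O)Nc2ccc(Oc3ccnc4[nH]ccc34)c(F)c2)nnn1-c1ccc(F)c(F)c1` — 610 nM
compound 2 `O=C(Nc1ccc(Oc2ccnc3[nH]ccc23)c(F)c1)c1nnn(-c2ccccc2)c1C(F)(F)F` — 91 nM

Compound 2 stands at the lowest of the two numbers in this assay; compound 1 gives a number that is markedly higher, a gap beyond the scatter. Compound 3 `O=C(Nc1ccc(Oc2ccnc3[nH]ccc23)c(F)c1)c1nnn(-c2ccc(F)c(F)c2)c1C(F)(F)F` is not yet measured. It differs from compound 2 in one place: 3,4-difluorophenyl in place of phenyl on an aromatic nitrogen. Among the compounds with values here, no measured pair shows this change on its own, so its effect on this assay is unknown. The expectation is a step of a 1.2-fold higher number from compound 2 to compound 3 (0.08 log units; within the scatter), small and within the scatter, in either direction. Compound 3 is estimated at 110 nM in this assay, with a range from 40 nM to 350 nM.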

Compound 3, half-maximal inhibitory concentration: 320 nM
Compound 3: middle estimate off by 2.9-fold (0.46 log units), on the low side, within the range that was stated.
By their numbers in this assay, from the lowest: compound 2; then compounds 3 and 1 (each within the scatter of the next).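

On the aromatic nitrogen, the swap from phenyl to 3,4-difluorophenyl is not neutral in this assay: it gives a 3.5-fold higher number from compound 2 to compound 3 (0.55 log units; beyond the scatter) beyond the scatter. With 3,4-difluorophenyl on that nitrogen, trifluoromethyl in place of methyl on the aromatic carbon gives a 1.9-fold lower number from compound 1 to compound 3 (0.28 log units; within the scatter) and so has no readable effect in this context. No measured property accounts for either step.

Still open, from the compounds shown here alone, is whether a single fluorine on the phenyl ring carries the step, and how a methoxy group or an amine on that ring would read. Going by these compounds, the effect of trifluoromethyl in place of methyl with plain phenyl on the nitrogen also remains open.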